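Heteroaryl amide swap and dog half-life in the series

A few compounds are considered here, and "the series" means these few. Any claim that something is new, unique, unknown or untested is made for them only; others in the source may bear on it.

Measured so far:
compound 1 `C[C@@H](NC(=O)C1(NC(=O)c2cncc(Br)c2)CC1)c1ccc(-n2nc(Cl)c3ccccc32)cc1F` gives 7.6 h in an in vivo ADME assay on the whole organism (strain Mongrel) for metabolic stability, with Canis familiaris (Canis lupus familiaris) as the target; a higher number here means that the compound lasts longer, a lower number that the compound disappears faster
compound 2 `COc1cc(C(=O)NC2(C(=O)N[C@H](C)c3ccc(-n4nc(Cl)c5ccccc54)cc3F)CC2)on1` gives 20.8 h in this assay
compound 3 `Cc1nnsc1C(=O)NC1(C(=O)N[C@H](C)c2ccc(-n3nc(Cl)c4ccccc43)cc2F)CC1` not yet measured in this assay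

Compound 2 stands highest of the two numbers in this assay; its nearest neighbour is compound 1, and the step of a 2.7-fold higher number from compound 1 to compound 2 (0.44 log units; beyond the scatter) separates them. The change to compound 3 is 4-methyl-1,2,3-thiadiazol-5-yl in place of 3-methoxy-1,2-oxazol-5-yl on a carbonyl carbon. Among the compounds with values here, the only measured step at this carbonyl carbon, a 2.7-fold higher number from compound 1 to compound 2 (0.44 log units; beyond the scatter), swapped a different pair of groups, so it bears on compound 3 only loosely. A modest shift, if any, is expected from compound 2 to compound 3, a 1.5-fold lower number from compound 2 to compound 3 (0.17 log units; within the scatter). For compound 3 the estimate in this assay is 14 h, with a range from 6 h to 32 h.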

Compound 3, half-life: 2.4 h
The estimate for compound 3 lay 5.8-fold (0.77 log units) above the measured number; the measured number lies below the stated range.
By their numbers in this assay, from the lowest: compound 3; then compound 1; then compound 2.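

Five-membered heteroaryl rings on this carbonyl carbon are not interchangeable in this assay even at similar size: replacing 3-methoxy-1,2-oxazol-5-yl with 4-methyl-1,2,3-thiadiazol-5-yl gives the largest step of the three (an 8.7-fold lower number from compound 2 to compound 3 (0.94 log units; beyond the scatter)). The same ring also falls short of 5-bromopyridin-3-yl (a 3.2-fold lower number from compound 1 to compound 3 (0.50 log units; beyond the scatter)), so changes at this place can move the half-life in either direction from compound 1. No evidence on the origin of the drop is available.

The compounds shown do not separate the effect of the ring from that of its substituent. A 3-methyl-1,2-oxazol-5-yl group on this carbonyl carbon would help to make that separation.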